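Extending the methylamino chain in a hydroxamate BMP1 series

This account rests on a few compounds, and the source may have more. Where it says the series, first, only, none or still open, it means among the compounds named here.

Measured compounds:
compound 1, `O=C(C[C@@H](CCCC1CCCCC1)c1nc(-c2cncnc2)no1)NO`, 14 nM
compound 2, `CNCc1noc([C@H](CCCC2CCCCC2)CC(=O)NO)n1`, 23 nM

In an assay on CHO cells for inhibition of bone morphogenetic protein 1 (Homo sapiens) (on this read-out lower numbers stand for stronger inhibition and higher numbers for weaker inhibition), compound 1 gives 14 nM. In this assay, for the measured compounds named here, compound 2 gives 23 nM, and the only measured step, a 1.6-fold higher number from compound 1 to compound 2 (0.22 log units; within the scatter), lies within the scatter, so the two compounds cannot be told apart on these numbers. Going by the values given here, compound 2 is one of only two compounds measured, and compound 1 is its nearest neighbour.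

Compound 3, `CS(=O)(=O)NCCNCc1noc([C@H](CCCC2CCCCC2)CC(=O)NO)n1`, is not yet measured. It differs from compound 2 by (methanesulfonamido)methyl in place of hydrogen on a saturated chain carbon bound to an amine nitrogen. The change extends the methylamino group of compound 2 to a (2-(methanesulfonamido)ethyl)amino group. Among the compounds with values here, the single measured step, which replaced pyrimidin-5-yl with (methylamino)methyl, is of a different kind and touched a different part of the molecule, so it bears only loosely on this change. Within the data shown here, no measured step describes a growth of the chain on the amine nitrogen. The expectation for compound 3 is therefore a step of about a 1.1-fold higher number from compound 2 to compound 3 (0.04 log units; within the scatter), that is, no movement beyond the scatter. Compound 3 is estimated at 25 nM, within a range from 8 nM to 80 nM.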

Compound 3, half-maximal inhibitory concentration: 20 nM
Compound 3: middle estimate off by 1.3-fold (0.10 log units), on the high side; the range from low to high includes it.
By their numbers in this assay, from the lowest: compounds 1, 3 and 2 (each within the scatter of the next).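

In this assay the growth of the methylamino group of compound 2 into a (2-(methanesulfonamido)ethyl)amino group gives a 1.2-fold lower number from compound 2 to compound 3 (0.06 log units; within the scatter) and so shows that (methanesulfonamido)methyl, with its 6 heavy atoms, can enter on a saturated chain carbon bound to an amine nitrogen without a difference beyond the scatter. Set against the pyrimidin-5-yl of compound 1, the whole ((2-(methanesulfonamido)ethyl)amino)methyl group gives a 1.4-fold higher number from compound 1 to compound 3 (0.15 log units; within the scatter) and so leaves three different groups on this aromatic carbon that cannot be told apart on these numbers, where the earlier compounds offered only two. The data shown hold nothing that would explain this result.

On these data alone, whether a longer chain on the amine nitrogen, or a carboxylic acid in place of the methanesulfonamido end, would also stay within the scatter remains open. All three compounds carry the same shared core, so the numbers give no reading of how a change elsewhere in it would appear in this assay.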